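A few compounds are considered here, and "the series" means these few. Any claim that something is new, unique, unknown or untested is made for them only; others in the source may bear on it.

Of the compounds shown here, two sharing a common core have been measured in a functional assay on K562 cells (Homo sapiens) for inhibition; a higher number here means a weaker inhibitor, a lower number a stronger inhibitor. Compound 1, `CC(=O)/C=C/c1ccc([N+](=O)[O-])cc1`, gives 2600 nM, and compound 2, `CC(=O)/C=C/c1cc(Br)ccc1F`, gives 5300 nM. Compound 1 therefore stands as the stronger inhibitor of the pair, and the gap between the two numbers lies beyond the usual scatter.

The next compound to be tested is compound 3, `CSc1ccc(/C=C/C(C)=O)cc1`, which keeps the core of compound 1 but carries methylsulfanyl in place of nitro on an aromatic carbon. Among the compounds with values here, no measured pair shows this kind of change, so the data offer no direct guide to it. Within the data shown here, the only reference points are compound 1 at 2600 nM and compound 2 at 5300 nM, and the expectation is correspondingly uncertain. Compound 1 holds the lower number, so a move upward in this assay seems more likely than a further gain, and a modest loss of inhibition is expected. The estimated step is a 2.5-fold higher number from compound 1 to compound 3 (0.40 log units; beyond the scatter). For compound 3 the estimated value is 6500 nM, with an expected range from 2500 nM to 18000 nM.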

Compound 3, half-maximal inhibitory concentration: 15000 nM
Compound 3: middle estimate off by 2.3-fold (0.36 log units), on the low side; the measured number falls inside the stated range.
By their numbers in this assay, from the lowest: compound 1; then compound 2; then compound 3.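

Within the data shown here, on an aromatic carbon para to a group of 5 heavy atoms, the exchange of nitro for methylsulfanyl is the first change in a single place to be measured, and in this assay it gives a 5.8-fold higher number from compound 1 to compound 3 (0.76 log units; beyond the scatter). The response at this carbon therefore depends on which group sits there: nitro, with its 3 heavy atoms and 2 hydrogen-bond acceptors, gives the stronger inhibitor of this pair, while methylsulfanyl, with 2 heavy atoms and 1 hydrogen-bond acceptor, gives the weaker. No information is available that accounts for this difference, and a single pair cannot show which feature of the two groups matters.

The compounds shown leave open whether the loss is particular to methylsulfanyl or would accompany other replacements of nitro at this carbon. They also do not tell how a nitrile, a methoxy group, an amine or a carboxylic acid in the same place would compare with nitro in this assay.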